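This account rests on a few compounds, and the source may have more. Where it says the series, first, only, none or still open, it means among the compounds named here.

Three compounds set the stage in an assay on ileum with muscarinic acetylcholine receptor M3 (Cavia porcellus) as the target; a lower number here means a stronger inhibitor, a higher number a weaker inhibitor. Compound 1, `CC(C)(C)NCCC(c1ccccc1)c1ccccc1`, gives 792 nM. Compound 2, `c1ccc(C(CCn2ccnc2)c2ccccc2)cc1`, gives 89.1 nM, and the change an 8.9-fold lower number from compound 1 to compound 2 (0.95 log units; beyond the scatter) marks the first step downward. Compound 3, `NC(=O)C(CCn1ccnc1)(c1ccccc1)c1ccccc1`, gives 5.07 nM, and the change an 18-fold lower number from compound 2 to compound 3 (1.24 log units; beyond the scatter) is the larger of the two steps. Compound 3 thus stands lowest of the three numbers, with compound 2 nearest and compound 1 furthest away, both gaps well beyond the scatter.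

The step to compound 4, `CCc1nccn1CCC(C(N)=O)(c1ccccc1)c1ccccc1`, keeps everything that made compound 3 the lowest and alters only one point: ethyl in place of hydrogen on an aromatic carbon, on an aromatic carbon of the five-membered aromatic ring with two nitrogens, between the two ring nitrogen atoms. Neither measured step bears on this change. The step from compound 1 to compound 2 swapped the whole group on the chain, and the step from compound 2 to compound 3 introduced carbamoyl on the chain carbon; nothing among the three shows what a small carbon group on the ring itself does. With no guide, the expectation is that compound 4 stays near compound 3, so the expected step is a 1.3-fold lower number from compound 3 to compound 4 (0.10 log units; within the scatter). Compound 4 is therefore estimated at 4 nM, within a range from 1.2 nM to 13 nM.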

Compound 4, antagonist equilibrium constant: 78.1 nM
The estimate for compound 4 lay 20-fold (1.29 log units) below the measured number, outside the stated range (above it).
By their numbers in this assay, from the lowest: compound 3; then compounds 4 and 2 (each within the scatter of the next); then compound 1.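

Ethyl in place of hydrogen on the aromatic carbon between two ring nitrogen atoms is the first change in this series to move the number upward, with a 15-fold higher number from compound 3 to compound 4 (1.19 log units; beyond the scatter) in this assay. This position on the imidazole of compound 3 is therefore far from indifferent: a substituent of only 2 heavy atoms, with no ring, no hydrogen-bond donors or acceptors and no net charge, is enough to undo much of the low number that compound 3 had reached. What the result shows is the size and direction of the step at this one place, while no measurement on hand offers an explanation for it.

The compounds shown leave open whether the rise tracks the size of the group, since a single methyl, a longer chain such as propyl, or a different kind of group such as an amine at this carbon might each give a different number. They also leave open whether ethyl on the other aromatic carbons of the same ring would raise the number as well, and whether the same change would have a similar effect on a chain without the carbamoyl.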